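Amide nitrogen substituent: from compound 3 to compound 4

The source may report more compounds than this note shows. Statements on the series, on what has been measured and on what is new or still open speak of the compounds shown alone.

Compound 1 `COc1cc(-c2nnc(SCC(=O)c3ccccc3)n2N)cc(OC)c1OC` carries a phenyl directly on the carbonyl carbon. In a functional assay on PC-3 cells (Homo sapiens) for antiproliferative activity, read by MTT assay, with a stated time of 48 h (a higher number here means a weaker inhibitor, a lower number a stronger inhibitor), compound 1 gives > 100000 nM, which is a limit of the assay and not a number (the limit of > 100000 nM in this assay, at which 1 of the 3 values shown sits). Compound 2 `COc1cc(-c2nnc(SCC(=O)Nc3ccccc3)n2N)cc(OC)c1OC` has an anilino in place of that phenyl; in this assay compound 2 gives 37900 nM. Compound 3 `COc1cc(-c2nnc(SCC(=O)Nc3ccccc3F)n2N)cc(OC)c1OC` carries a (2-fluorophenyl)amino instead; in this assay compound 3 gives 36700 nM. The two measured steps from the limit compound are an at least 2.6-fold lower number from compound 1 to compound 2 (0.42 log units; beyond the scatter) and an at least 2.7-fold lower number from compound 1 to compound 3 (0.43 log units; beyond the scatter). Between the two amides the step is a 1.0-fold lower number from compound 2 to compound 3 (0.01 log units; within the scatter), so compound 3 and compound 2 sit together within the scatter, with the only other value being a limit.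

Compound 4 `COc1ccc(CNC(=O)CSc2nnc(-c3cc(OC)c(OC)c(OC)c3)n2N)cc1OC` differs from compound 3 by 3,4-dimethoxybenzyl in place of 2-fluorophenyl on an amide-type nitrogen. Going by the values given here, the only measured step that touches the group on the amide-type nitrogen is a 1.0-fold lower number from compound 2 to compound 3 (0.01 log units; within the scatter), a change on an aromatic ring that stayed within the scatter. Among the compounds with values here, no measured step exchanges an aromatic ring for a benzyl on this nitrogen, so the expectation rests on the amide values alone. The expected step in this assay is a 1.0-fold lower number from compound 3 to compound 4 (0.02 log units; within the scatter), not beyond the scatter. Compound 4 is therefore estimated at 35000 nM, within 12000 nM to 100000 nM.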

Compound 4, half-maximal inhibitory concentration: > 100000 nM
Compound 4: a limit, no number; the forecaster's own chance of this, stated with the estimate: 20%; middle value at least 2.8-fold (0.45 log units) away from the limit.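

In this assay the amide-type nitrogen proves sensitive to its substituent. The earlier change on this group, fluoro on the aromatic ring, stayed within the scatter, whereas 3,4-dimethoxybenzyl in place of 2-fluorophenyl gives an at least 2.7-fold higher number from compound 3 to compound 4 (0.43 log units; beyond the scatter), and in place of phenyl it gives an at least 2.6-fold higher number from compound 2 to compound 4 (0.42 log units; beyond the scatter). The result for compound 4 is a limit of the assay and not a number, so both steps are known only as bounds: the limit of > 100000 nM in this assay, at which 2 of the 4 values shown sit.

Among the compounds shown, only compound 2 and compound 3, with an aromatic ring directly on the amide-type nitrogen, give numbers, while compound 1 and compound 4 stand at the limit; this holds for these four compounds alone.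

The 3,4-dimethoxybenzyl group changes two things at once, so the compounds shown do not separate the effect of the added carbon on the nitrogen from that of the two methoxy groups, and an unsubstituted benzyl on this nitrogen would divide them. As far as these compounds go, it also remains open whether methoxy groups, a dimethylamino group or a carboxylic acid on the anilino ring would move the number away from those of compound 2 and compound 3.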